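Triazole-linked spirooxindoles: a closer look at the aryl group

The compounds below may be only part of what the source reports. "The series", "measured", "known", "first", "only" and "open" are said of these compounds alone.

Measured compounds:
Compound 1 `N#CC1=C(N)Oc2c(c3nc4ccccc4nc3c3ccccc23)C12C(=O)N(Cc1cnnn1-c1ccccc1Cl)c1ccccc12` in a functional assay on HepG2 cells (Homo sapiens) for antiproliferative activity, read by MTT assay, with a stated time of 48 h (on this read-out higher numbers stand for weaker inhibition and lower numbers for stronger inhibition), gives > 50000 nM, which is a limit of the assay.
Compound 2 `N#CC1=C(N)Oc2c(c3nc4ccccc4nc3c3ccccc23)C12C(=O)N(Cc1cnnn1-c1cccc(Cl)c1)c1ccccc12` in this assay gives > 50000 nM, also a limit of the assay.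
Compound 3 `Cc1ccc(Cl)cc1-n1nncc1CN1C(=O)C2(C(C#N)=C(N)Oc3c2c2nc4ccccc4nc2c2ccccc32)c2ccccc21` in this assay gives > 50000 nM, again a limit of the assay.

Compound 3 thus stands where every measured compound stands: at a limit, with no number that would set it apart from the others. The three compounds share one core and differ only in the aryl group attached to the triazole nitrogen, yet none of these changes can be read, as a step that the two limits leave unreadable from compound 1 to compound 2, a step that the two limits leave unreadable from compound 1 to compound 3 and a step that the two limits leave unreadable from compound 2 to compound 3 show; the limit of > 50000 nM in this assay, at which 3 of the 3 values shown sit, is all the evidence there is.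

Compound 4 `N#CC1=C(N)Oc2c(c3nc4ccccc4nc3c3ccccc23)C12C(=O)N(Cc1cnnn1-c1ccc(F)c(Cl)c1)c1ccccc12` is not yet measured. Its change from compound 3 is 3-chloro-4-fluorophenyl in place of 5-chloro-2-methylphenyl on an aromatic nitrogen. Since all comparable steps are unreadable and every measured value sits at the limit, no direction or size of step can be derived beyond the scatter. The expected step is a step that the limit leaves unreadable from compound 3 to compound 4, most likely again ending at a limit. Compound 4 is therefore estimated at 80000 nM, in the range 30000 nM to 300000 nM.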

Compound 4, half-maximal inhibitory concentration: > 50000 nM
Compound 4: only a limit was reported; the forecaster's own chance of this, stated with the estimate: 80%; the middle value does not contradict the limit.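

In this assay compound 4 gives > 50000 nM, a limit of the assay. Its steps to compound 1, compound 2 and compound 3 cannot be read: the limit of > 50000 nM in this assay, at which 4 of the 4 values shown sit. The compounds shown leave open how strongly each inhibits, and whether changing the aryl group alters that at all.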